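The compounds below may be only part of what the source reports. "The series", "measured", "known", "first", "only" and "open" are said of these compounds alone.

Measured so far in a functional assay on U-87MG ATCC cells (Homo sapiens) for cytotoxicity, read by MTT assay, with a stated time of 72 h; a lower number here means a stronger inhibitor, a higher number a weaker inhibitor:
- compound 1 `CN(C)CCn1cnnc1-c1cc(Oc2ccc(NC(=O)N/N=C/c3c[nH]c4ccccc34)cc2F)ccn1`: 690 nM
- compound 2 `CN(C)CCn1cnnc1-c1cc(Oc2ccc(NC(=O)N/N=C/c3ccc(O)c(Br)c3)cc2F)ccn1`: 12400 nM
- compound 3 `CN(C)CCn1cnnc1-c1cc(Oc2ccc(NC(=O)N/N=C/c3ccc(O)cc3)cc2F)ccn1`: 7750 nM

Compound 3 holds the second highest of the three numbers. Its nearest neighbour is compound 2, with a 1.6-fold lower number from compound 2 to compound 3 (0.20 log units; within the scatter); its furthest is compound 1, with an 11-fold higher number from compound 1 to compound 3 (1.05 log units; beyond the scatter).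

Compound 4 `CN(C)CCn1cnnc1-c1cc(Oc2ccc(NC(=O)N/N=C/c3ccc(O)c(F)c3)cc2F)ccn1` differs from compound 3 by fluoro in place of hydrogen on an aromatic carbon. For the measured compounds named here, the only step that bears on this change is the bromo-to-hydrogen step on the same aromatic carbon, a 1.6-fold lower number from compound 2 to compound 3 (0.20 log units; within the scatter), which stays inside the scatter. A fluoro at that carbon is therefore expected to give a step, a 1.2-fold higher number from compound 3 to compound 4 (0.06 log units; within the scatter), that also stays inside the scatter, with no clear direction. For compound 4 the expected value in this assay is 9000 nM, with a range from 4000 nM to 20000 nM.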

Compound 4, half-maximal inhibitory concentration: > 100000 nM
Compound 4 ended at the assay's limit (the forecaster's own chance of this, stated with the estimate: 5%); middle value at least 11-fold (1.04 log units) from the limit.
By their numbers in this assay, from the lowest: compound 1; then compounds 3 and 2 (each within the scatter of the next). At a limit, above all of these: compound 4.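

In this assay compound 4 stands at a limit of the assay and not at a number: the limit of > 100000 nM in this assay, at which 1 of the 4 values shown sits.
On this aromatic carbon, ortho to a hydroxy group, a single fluoro is enough for a large step from the hydrogen compound (an at least 12-fold higher number from compound 3 to compound 4 (1.11 log units; beyond the scatter)), whereas bromo and hydrogen stay within the scatter of each other, and fluoro also parts from bromo (an at least 8.0-fold higher number from compound 2 to compound 4 (0.90 log units; beyond the scatter)). The gap to the 1H-indol-3-yl compound widens as well (an at least 140-fold higher number from compound 1 to compound 4 (2.16 log units; beyond the scatter)).

As far as these compounds go, how far compound 4 lies past the limit remains open. Also open, from the compounds shown here alone, is whether chloro or methoxy on the same carbon would track with bromo or with fluoro.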